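The source may hold more compounds than are shown below. What is called first, only, known or untested is meant among the compounds shown, and "the series" means these compounds.

Measured in an ADME assay on a cell-free system (plasma, Homo sapiens) for metabolic stability, read by LC-MS, using NADPH, with a stated time of 60 min, tested at 1 uM; on this read-out higher numbers stand for a more stable compound and lower numbers for a less stable compound:
- Compound 1 `CNC(=O)c1cc(S(=O)(=O)N2CCS[C@H]2C(=O)O[C@@H](Cc2c(Cl)c[n+]([O-])cc2Cl)c2ccc(OC(F)F)c(OCC3CC3)c2)cn1C`: 100%
- Compound 2 `COc1ccc(S(=O)(=O)N2CCC[C@H]2C(=O)O[C@@H](Cc2c(Cl)c[n+]([O-])cc2Cl)c2ccc(OC(F)F)c(OCC3CC3)c2)cc1C(=O)N(C)C`: 101%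
- Compound 3 `Cn1cnc(S(=O)(=O)N2CCS[C@H]2C(=O)O[C@@H](Cc2c(Cl)c[n+]([O-])cc2Cl)c2ccc(OC(F)F)c(OCC3CC3)c2)c1`: 101%

Compound 3 shares the top number of this small set with compound 2, and compound 1 lies within the scatter of both. Compound 4 `COc1ccc(S(=O)(=O)N2CCS[C@H]2C(=O)O[C@@H](Cc2c(Cl)c[n+]([O-])cc2Cl)c2ccc(OC(F)F)c(OCC3CC3)c2)cc1OC` carries 3,4-dimethoxyphenyl in place of 1-methyl-1H-imidazol-4-yl on a sulfonyl sulfur. Going by the values given here, one measured step bears on this, an exchange on the same sulfonyl sulfur: a number 1 percentage points higher from compound 1 to compound 3 (within the scatter). A step of similar size is therefore expected, with nothing beyond the scatter. The estimated change is a number 4 percentage points lower from compound 3 to compound 4 (within the scatter). Among the compounds with values here, no measured compound carries 3,4-dimethoxyphenyl, so the range is kept wide. In this assay, compound 4 is expected at 97%, within an estimated range of 85% to 106%.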

Compound 4, percent of the compound remaining: 101%
For compound 4 the middle estimate is 4 percentage points below the measured one, within the range that was stated.
By their numbers in this assay, from the lowest: compounds 1, 2, 3 and 4 (each within the scatter of the next).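

In this assay, placing 3,4-dimethoxyphenyl on the sulfonyl sulfur gives no change at the digits printed from compound 3 to compound 4 (within the scatter), and the comparison with the larger amide-bearing group gives a number 1 percentage points higher from compound 1 to compound 4 (within the scatter). This position therefore now holds a six-membered aromatic ring of carbon only, as well as two different five-membered aromatic rings, with all three compounds within the scatter of one another. No measurement at hand explains why the read-out stays level. On these data alone, whether it would stay level with a carboxylic acid or an amine on this ring remains open.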